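The source may hold more compounds than are shown below. What is called first, only, known or untested is meant among the compounds shown, and "the series" means these compounds.

a functional assay on A-375 cells (Homo sapiens) for inhibition, read by MTT assay, with a stated time of 24 h (a lower number here means a stronger inhibitor, a higher number a weaker inhibitor), has been run on three compounds that share one core. Compound 1 (`COc1cccc(N2CCN(c3c(CO)c(=O)oc4ccccc34)CC2)c1`) gives 6510 nM. Compound 3 (`O=c1oc2ccccc2c(N2CCN(C(c3ccccc3)c3ccc(Cl)cc3)CC2)c1CO`) gives 3890 nM, within the scatter of the value for compound 1. Compound 2 (`O=c1oc2ccccc2c(N2CCN(c3ccccc3)CC2)c1CO`) gives 17300 nM, a number clearly higher than that of compound 1.

Compound 4 (`O=c1oc2ccccc2c(N2CCN(c3ccc(F)cc3)CC2)c1CO`) has not yet been measured. Its difference from compound 1 is 4-fluorophenyl in place of 3-methoxyphenyl on an amine nitrogen in a ring, which in words is 4-fluorophenyl in place of 3-methoxyphenyl on an amine nitrogen in a ring.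

Within the data shown here, only one measured step bears on this change. It is a 2.7-fold higher number from compound 1 to compound 2 (0.42 log units; beyond the scatter), seen when hydrogen takes the place of methoxy on an aromatic carbon. Compound 4 also lacks the methoxy, so a move in the same upward direction is expected in this assay. Among the measured compounds shown here, it carries a fluorine, however, and no measured compound shows what that brings. The expected step is therefore smaller than the measured one and may not clear the scatter. The estimated step is a 1.5-fold higher number from compound 1 to compound 4 (0.19 log units; within the scatter). For compound 4 the expected value is 10000 nM, with an estimated range of 4500 nM to 22000 nM.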

Compound 4, half-maximal inhibitory concentration: 24700 nM
Compound 4: the middle estimate sits 2.5-fold (0.39 log units) below what was measured; measured number above the stated range.
By their numbers in this assay, from the lowest: compounds 3 and 1 (each within the scatter of the next); then compounds 2 and 4 (each within the scatter of the next).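

In this assay, the new result shows that the fluoro group does not restore what is lost when the methoxy group goes: 4-fluorophenyl in place of 3-methoxyphenyl on the amine nitrogen in the ring gives a 3.8-fold higher number from compound 1 to compound 4 (0.58 log units; beyond the scatter). The step that isolates the fluorine, a 1.4-fold higher number from compound 2 to compound 4 (0.15 log units; within the scatter), cannot be told apart from no change, so at this position compound 2 and compound 4 stand level within the scatter. Of the three compounds with a single substituted or plain phenyl group on that nitrogen, compound 1 alone now stands apart from both others, and nothing measured here explains why.

The compounds shown leave open whether it is the methoxy group itself that matters, or whether a hydroxy group, an ethoxy group or an amine carried on the same phenyl ring would serve as well. They also leave open whether a chloro group or a trifluoromethyl group on the phenyl ring would behave as the fluoro group does, and whether the methoxy group would keep its effect at another place on that ring.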